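This account rests on a few compounds, and the source may have more. Where it says the series, first, only, none or still open, it means among the compounds named here.

Measured in a functional assay on A-375 cells (Homo sapiens) for antiproliferative activity, read by MTT assay, with a stated time of 24 h, tested at 0.01 ug/mL; on this read-out higher numbers stand for a stronger effect at the one concentration tested and lower numbers for a weaker effect:
compound 1 `COc1ccc2nc(C(=O)Nc3ccc(-c4ccccc4)cc3)c(C)c(O)c2c1`: 0.13%
compound 2 `Cc1c(C(=O)Nc2ccc(-c3ccccc3)cc2)nc2ccccc2c1O`: -0.11%
compound 3 `CCOc1ccc2nc(C(=O)Nc3c(F)cc(-c4cccc(F)c4)cc3F)c(C)c(C(=O)O)c2c1`: 0.3%

Compound 1 stands second highest of the three numbers in this assay, with compound 3 nearest and compound 2 furthest, both of them within the scatter of compound 1. Among the measured compounds shown here, the one measured step, a number 0.2 percentage points lower from compound 1 to compound 2 (within the scatter), is within the scatter. Compound 4 `COc1ccc2nc(C(=O)Nc3ccc(-c4ccccc4)cc3)c(C)c(C(=O)O)c2c1` differs from compound 1 by carboxy in place of hydroxy on an aromatic carbon. For the measured compounds named here, no measured step bears on this change; compound 3, which also carries a carboxy group, differs from compound 1 in several further places, and its value sits within the scatter of compound 1. The step of a number 0.1 percentage points higher from compound 1 to compound 4 (within the scatter) is therefore expected to stay within the scatter. Compound 4 is estimated at 0.2%, in a range from -4% to 5%.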

Compound 4, a percentage reported as inhibition, at one concentration (the size of the read-out at that concentration, not a potency): 0.35%
Compound 4: the middle estimate sits 0.2 percentage points below what was measured; the measured number falls inside the stated range.
By their numbers in this assay, from the lowest: compounds 2, 1, 3 and 4 (each within the scatter of the next).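

Among the compounds shown here, the step of a number 0.2 percentage points higher from compound 1 to compound 4 (within the scatter) in this assay gives the first direct reading at the carbon opposite the ring nitrogen, and carboxy in place of hydroxy there produces no difference beyond the scatter at the one concentration tested. The comparison no longer rests on compound 3, which differs from compound 1 in several further places. No supporting data bear on this result.

Going by these compounds, whether an amine or a methyl ester at this carbon would separate from compound 1 remains open. So does whether any of these compounds would give a clear effect at a higher concentration.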